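Chloro added to the shared core: compound 1 to compound 3

The compounds below may be only part of what the source reports. "The series", "measured", "known", "first", "only" and "open" are said of these compounds alone.

Measured so far:
compound 1 `ClCc1cccc(Cn2cnc3ncnc(Cl)c32)c1` — 20000 nM
compound 2 `ClCc1ccc(Cn2cnc3nc(Cl)nc(Cl)c32)cc1` — 1860 nM

In a functional assay on SF-539 cells (Homo sapiens) for cytotoxicity, read by sulforhodamine B assay, with a stated time of 48 h (on this read-out lower numbers stand for stronger inhibition of growth and higher numbers for weaker inhibition of growth), compound 1 gives 20000 nM, the highest number of the two; compound 2, its nearest neighbour, lies beyond the scatter below it. Compound 3 `ClCc1cccc(Cn2cnc3nc(Cl)nc(Cl)c32)c1` differs from compound 1 by chloro in place of hydrogen on an aromatic carbon. Among the measured compounds shown here, no pair of measured compounds differs in this one place only, and compound 2 differs from compound 1 in two places, so its value shows a combined change. The step from compound 1 to compound 3 is nevertheless expected to lie beyond the scatter toward lower numbers, estimated as a 5.0-fold lower number from compound 1 to compound 3 (0.70 log units; beyond the scatter). For compound 3 the expected value is 4000 nM, with a range from 1500 nM to 12000 nM.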

Compound 3, concentration for 50% growth inhibition: 160 nM
Compound 3: the middle estimate sits 25-fold (1.40 log units) above what was measured; measured number outside the range, below it.
By their numbers in this assay, from the lowest: compound 3; then compound 2; then compound 1.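

In this assay, among the compounds shown here, the step of a 130-fold lower number from compound 1 to compound 3 (2.10 log units; beyond the scatter) gives the first reading of a change in this one place, since the earlier pair carried a combined change. Chloro in place of hydrogen on this aromatic carbon, between two ring nitrogen atoms, therefore makes a large difference on its own in this pair. No measurement here accounts for the size of this step. On these data alone, it remains open whether this depends on chloro itself or would also appear with an amine or a methoxy group at this position. A single pair also leaves open whether the step holds with the chloromethyl group placed elsewhere on the benzyl ring.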